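Trifluoromethoxy for Trifluoromethyl on a Shared Core

This account rests on a few compounds, and the source may have more. Where it says the series, first, only, none or still open, it means among the compounds named here.

Four compounds share one core and differ only in a single group on one ring. Compound 1 `O=C(/C=C/c1ccccc1C(F)(F)F)c1ccccc1` carries a trifluoromethyl group. In a functional assay on RAW264.7 cells (Mus musculus) for inhibition, read by fluorescence, with stated times of 1 h, 24 h and 30 min (a higher number here means a weaker inhibitor, a lower number a stronger inhibitor), compound 1 gives only a limit of the assay, > 10000 nM. Compound 2 `O=C(/C=C/c1ccc(C(F)(F)F)cc1)c1ccccc1` has the same atoms as compound 1, joined differently; the difference between the two cores is not broken down here. In this assay compound 2 likewise gives a limit, > 10000 nM. Compound 3 `O=C(/C=C/c1ccccc1OC(F)(F)F)c1ccccc1` differs from compound 1 by trifluoromethoxy in place of trifluoromethyl on an aromatic carbon. In this assay compound 3 gives a limit, > 10000 nM. The change from compound 1 to compound 3 therefore yields a step that the two limits leave unreadable from compound 1 to compound 3, because of the limit of > 10000 nM in this assay, at which 3 of the 3 values shown sit. Compound 4 `O=C(/C=C/c1ccc(OC(F)(F)F)cc1)c1ccccc1` is not yet measured; it differs from compound 2 by trifluoromethoxy in place of trifluoromethyl on an aromatic carbon. This is the same kind of change as from compound 1 to compound 3, not the same: there the place is ortho to a large group, here it is para to a large group. For compound 4 the expected step is a step that the limit leaves unreadable from compound 2 to compound 4, because of the limit of > 10000 nM in this assay, at which 3 of the 3 values shown sit. In this assay compound 4 is estimated at 15000 nM.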

Compound 4, half-maximal inhibitory concentration: > 10000 nM
Compound 4: a limit, no number; the forecaster's own chance of this, stated with the estimate: 80%; the middle value does not contradict the limit.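

In this assay compound 4 gives > 10000 nM as a limit and not a number. The size of the step from compound 2 to compound 4 therefore cannot be read, and the reason is this: the limit of > 10000 nM in this assay, at which 4 of the 4 values shown sit. The compounds shown leave open whether trifluoromethoxy in place of trifluoromethyl changes inhibition at all, since none of the four gives a measured number in this assay.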